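The compounds below may be only part of what the source reports. "The series", "measured", "known", "first", "only" and "open" are said of these compounds alone.

Among the measured compounds shown here, compound 1 `N#CC1(NC(=O)[C@@H]2C[C@@H](S(=O)(=O)c3ccccc3)C[C@H]2C(=O)N2CCOCC2)CC1` gives the lowest of the two numbers so far: in an assay on isolated protein for inhibition of cathepsin S (Homo sapiens), read by fluorescence, with a stated time of 20 min (on this read-out lower numbers stand for stronger inhibition and higher numbers for weaker inhibition), compound 1 gives 0.7 nM. Compound 2 `N#CC1(NC(=O)[C@@H]2C[C@@H](S(=O)(=O)c3ccccc3)C[C@H]2C(=O)N2CCOCC2)CCC1` gives 4 nM, and a 5.7-fold higher number from compound 1 to compound 2 (0.76 log units; beyond the scatter). Compound 3 `C[C@@H]1CN(C(=O)[C@@H]2C[C@H](S(=O)(=O)c3ccccc3)C[C@H]2C(=O)NC2(C#N)CC2)C[C@H](C)O1` differs from compound 1 elsewhere: 2,6-dimethylmorpholin-4-yl in place of morpholin-4-yl on a carbonyl carbon. For the measured compounds named here, no measured step touches that part of the core, so the only guide is that the shared core holds its strong inhibition through the change from compound 1 to compound 2. A step no larger than the scatter is expected, so a 1.4-fold higher number from compound 1 to compound 3 (0.15 log units; within the scatter); compound 3 is estimated at 1 nM, within 0.3 nM to 3.5 nM.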

Compound 3, half-maximal inhibitory concentration: 0.4 nM
Compound 3: middle estimate off by 2.5-fold (0.40 log units), on the high side; measured number inside the range.
By their numbers in this assay, from the lowest: compounds 3 and 1 (each within the scatter of the next); then compound 2.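

The first change shown on this carbonyl carbon leaves inhibition in this assay essentially unchanged (a 1.8-fold lower number from compound 1 to compound 3 (0.24 log units; within the scatter)). So 2,6-dimethylmorpholin-4-yl, with more heavy atoms and 2 defined stereocentres, serves here as well as morpholin-4-yl. No evidence is available to explain this match.

Still open, going by these compounds, is whether a piperidin-1-yl group or an open-chain dimethylamino group on this carbonyl carbon would hold inhibition as well. Also open, on these data alone, are the part played by the stereocentres and whether the same change would behave alike with the 1-cyanocyclobutyl group of compound 2.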